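This account rests on a few compounds, and the source may have more. Where it says the series, first, only, none or still open, it means among the compounds named here.

Three compounds tested in an assay on isolated protein for inhibition of prostaglandin E2 receptor EP3 subtype (Homo sapiens) (a higher number here means a weaker inhibitor, a lower number a stronger inhibitor), share one core and differ in two places. Compound 1 `O=C(O)c1cccc(C2=C(c3cc(Br)ccc3OCc3ccc(F)cc3)CCC2)c1` gives < 3170 nM in this assay, a limit rather than a number. Compound 2 `O=C(O)c1cccc(C2=C(c3cc(Br)ccc3OCc3ccc(F)cc3F)CCC2)c1` gives < 3170 nM, again a limit. Compound 3 `CSc1ccc(OCc2ccc(F)cc2)c(C2=C(c3cccc(C(=O)O)c3)CCC2)c1` gives < 3170 nM, also a limit. The steps a step that the two limits leave unreadable from compound 1 to compound 2 and a step that the two limits leave unreadable from compound 1 to compound 3 therefore cannot be read, since all three values rest at the limit of < 3170 nM in this assay, at which 3 of the 3 values shown sit. Compound 4 `CSc1ccc(OCc2ccccc2)c(C2=C(c3cccc(C(=O)O)c3)CCC2)c1` differs from compound 3 by hydrogen in place of fluoro on an aromatic carbon. Neither measured step touches this change, and neither is readable. With nothing to point elsewhere, compound 4 is expected to show a step that the limit leaves unreadable from compound 3 to compound 4, nothing beyond the scatter. Compound 4 is accordingly estimated at 1000 nM, within 100 nM to 5000 nM.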

Compound 4, half-maximal inhibitory concentration: < 3170 nM
Compound 4 ended at the assay's limit; the forecaster's own chance of this, stated with the estimate: 60%; the middle value is on the limit's open side.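

Compound 4 adds no readable step to compound 3, because the values of both compounds rest at one limit: the limit of < 3170 nM in this assay, at which 4 of the 4 values shown sit.

Going by these compounds, how strongly each of the four compounds inhibits, and what replacing 4-fluorobenzyl with benzyl does, remains open.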